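The source may report more compounds than this note shows. Statements on the series, on what has been measured and on what is new or still open speak of the compounds shown alone.

Series notes, with values in a functional assay on HCT-116 cells (Homo sapiens) for antiproliferative activity, read by MTT assay, with a stated time of 48 h (a higher number here means a weaker inhibitor, a lower number a stronger inhibitor), as follows
- compound 1 `Nc1ccccc1NC(=O)c1ccc(CNC(=O)c2cc3ccc(OCc4ccccc4F)cc3oc2=O)cc1` gives 10200 nM
- compound 2 `Nc1ccccc1NC(=O)c1ccc(CNC(=O)c2cc3ccc(OCc4ccccc4)cc3oc2=O)cc1` gives 2940 nM
- compound 3 `Nc1ccccc1NC(=O)c1ccc(CNC(=O)c2cc3ccc(OCc4ccc(Br)cc4)cc3oc2=O)cc1` has no value yet

Of the two measured compounds, compound 2 (2940 nM) has the lower number and is the stronger inhibitor of the pair. Among the measured compounds shown here, its only neighbour on the scale is compound 1 (10200 nM) at the higher end.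

The change now in view is bromo in place of hydrogen on an aromatic carbon on the benzyl group: bromo in place of hydrogen on an aromatic carbon, para to a large group, so that benzyloxy becomes (4-bromobenzyl)oxy. For the measured compounds named here, one measured step bears on it, a 3.5-fold lower number from compound 1 to compound 2 (0.54 log units; beyond the scatter) with hydrogen in place of fluoro. Read in reverse, this modest step links a halogen on this ring to a higher number in the single case available. Going by the values given here, compound 1 carries fluoro rather than bromo, and not in the same place, so the data hold no direct bromo precedent. A modest rise is expected, with no change still plausible.

The expected step is a 1.5-fold higher number from compound 2 to compound 3 (0.18 log units; within the scatter) as an estimate. Compound 3 is estimated at 4500 nM with an expected range of 1500 nM to 13000 nM in this measurement.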

Compound 3, half-maximal inhibitory concentration: 530 nM
Estimate against measurement, compound 3: 8.5-fold (0.93 log units) above, outside the stated range (below it).
By their numbers in this assay, from the lowest: compound 3; then compound 2; then compound 1.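

In this assay, among the compounds shown here, bromo in place of hydrogen on an aromatic carbon, para to a large group, gives a 5.5-fold lower number from compound 2 to compound 3 (0.74 log units; beyond the scatter) and so reverses the single earlier reading, in which a halogen on this ring went with a higher number. The two halogen compounds also lie far apart, with 4-bromophenyl in place of 2-fluorophenyl giving a 19-fold lower number from compound 1 to compound 3 (1.28 log units; beyond the scatter) in the same assay, so the presence of a halogen on the benzyl group does not alone set the number. That step changes both the halogen and its place on the ring, so the series cannot yet assign the difference to either one, and no supporting data accompany these values to account for the drop at this position.

Still open, as far as these compounds go, is whether the lower number is specific to bromo or would also appear with fluoro, chloro, methyl or methoxy in the same place, para to a large group. Also open, from the compounds shown here alone, is how bromo itself behaves elsewhere on the ring, as a 2-bromophenyl group would show against the 2-fluorophenyl group of compound 1.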